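The source may hold more compounds than are shown below. What is called first, only, known or untested is meant among the compounds shown, and "the series" means these compounds.

Measured compounds:
compound 1 `O=C1COc2ccc(-c3cnc(Cl)c(NS(=O)(=O)c4ccc(F)cc4)c3)cc2N1c1ccccc1`, 10300 nM
compound 2 `COc1cccc(N2C(=O)COc3ccc(-c4ccc(O)cc4)cc32)c1`, > 40000 nM

In a functional assay on HeLa cells (Homo sapiens) for antiproliferative activity, read by MTT assay, with a stated time of 72 h (a higher number here means a weaker inhibitor, a lower number a stronger inhibitor), compound 1 gives 10300 nM. This is the only number shown in this assay. Compound 2 gives > 40000 nM in this assay, which is a limit of the assay and not a number; the point on record for it is the limit of > 40000 nM in this assay, at which 1 of the 2 values shown sits.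

Compound 3 `Cc1ccc(N2C(=O)COc3ccc(-c4cnc(Cl)c(NS(=O)(=O)c5ccc(F)cc5)c4)cc32)cc1` shares the core of compound 1 and differs from it in one place: methyl in place of hydrogen on an aromatic carbon. The sulfonamide, the chlorine on the pyridine and the fluorine-bearing ring are kept. For the measured compounds named here, no step between measured compounds covers this change, so there is nothing to set its size from. The step from compound 1 to compound 3 in this assay is expected to stay within the usual scatter, with no clear direction, at a 1.1-fold lower number from compound 1 to compound 3 (0.06 log units; within the scatter). The value of compound 3 in this assay is estimated at 9000 nM, within 3000 nM to 27000 nM.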

Compound 3, half-maximal inhibitory concentration: 32300 nM
Compound 3: middle estimate off by 3.6-fold (0.55 log units), on the low side, and the stated range ends below it.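

In this assay, for the compounds shown here, the change from phenyl to 4-methylphenyl gives a 3.1-fold higher number from compound 1 to compound 3 (0.50 log units; beyond the scatter) and is the first single-place step that can be read. This position, para to a large group, is therefore not indifferent: with the sulfonamide, the chlorine on the pyridine and the fluorine-bearing ring kept, one added methyl moves the number towards a weaker inhibitor. Nothing on record bears on the reason for this step.

Open, as far as these compounds go, is whether this move is particular to methyl or extends to other groups at the same place, such as ethyl, an amine or a carboxylic acid. Also open, from the compounds shown here alone, is whether methyl at this place would give a step of similar size on a compound without the sulfonamide.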